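Swapping the Aminohexyl Chain for a Hydroxyethyl Group

This account rests on a few compounds, and the source may have more. Where it says the series, first, only, none or still open, it means among the compounds named here.

Measured compounds in a functional assay on HCT-116 cells (Homo sapiens) for cytotoxicity, read by MTT assay, with a stated time of 72 h; on this read-out lower numbers stand for stronger inhibition and higher numbers for weaker inhibition:
- compound 1 `O=C(NCc1ccc(F)cc1)c1nc(Br)c2cccnc2c1NCc1ccccc1`: > 20000 nM
- compound 2 `C[C@H](Nc1c(C(=O)NCc2ccc(F)cc2)nc(Br)c2cccnc12)c1ccccc1`: > 20000 nM
- compound 3 `NCCCCCCNc1c(C(=O)NCc2ccc(F)cc2)nc(Br)c2cccnc12`: 7000 nM

The value of compound 1 is a limit of the assay, not a number. The value of compound 2 is likewise a limit. Among the compounds with values here, compound 3 therefore stands as the only compound here with a measured number, and it sits at the strong end of what the three show. Moving from the phenyl-bearing side chains to the aminohexyl chain gave an at least 2.8-fold lower number from compound 1 to compound 3 (0.45 log units; beyond the scatter) and an at least 2.8-fold lower number from compound 2 to compound 3 (0.45 log units; beyond the scatter), both reading as at least modest because of the limit of > 20000 nM in this assay, at which 2 of the 3 values shown sit.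

Compound 4 `O=C(NCc1ccc(F)cc1)c1nc(Br)c2cccnc2c1NCCO` is not yet measured. It differs from compound 3 by hydroxy in place of 4-aminobutyl on a saturated chain carbon, two bonds along the chain from a nitrogen on an aromatic ring. The two measured steps both point to the 6-aminohexyl chain as what set compound 3 apart from its two limit-bound neighbours, so removing most of that chain is expected to move the number back toward those limits: an estimated 2.9-fold higher number from compound 3 to compound 4 (0.46 log units; beyond the scatter). For compound 4 the estimate is 20000 nM, with a range from 7000 nM to 60000 nM.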

Compound 4, half-maximal inhibitory concentration: > 20000 nM
Compound 4 was reported as a limit (the forecaster's own chance of this, stated with the estimate: 60%); the middle value sits exactly at the limit.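

At this position, the chain end matters more than the mere absence of a phenyl group. In this assay, going to the 2-hydroxyethyl chain gives an at least 2.8-fold higher number from compound 3 to compound 4 (0.45 log units; beyond the scatter), even though the group that leaves and the group that enters have the same counts of hydrogen-bond donors and acceptors, so those counts do not account for the difference. The value of compound 4 is a limit and not a number, and the steps from compound 1 and compound 2 to compound 4 cannot be read: the limit of > 20000 nM in this assay, at which 3 of the 4 values shown sit.

Chain length and the terminal amine changed together, so their contributions remain unseparated. A hexyl chain ending in hydroxy and an ethyl chain ending in an amine would tell them apart, while a longer chain ending in an amine would show whether the number can fall further.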